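Removing the ring methyl from the amide of compound 3

The source may report more compounds than this note shows. Statements on the series, on what has been measured and on what is new or still open speak of the compounds shown alone.

Compound 1 `Cc1ccccc1C(=O)OC(CCN(C)C)c1ccc(Cl)cc1`: 126%
Compound 2 `COc1cccc(C(=O)OC(CCN(C)C)c2ccc(Cl)cc2)c1C`: 88%
Compound 3 `Cc1ccccc1C(=O)NC(CCN(C)C)c1ccc(Cl)cc1`: 175%

In an assay on NIH3T3 cells with Urotensin-2 receptor (Homo sapiens) as the target (on this read-out higher numbers stand for larger maximal responses and lower numbers for smaller maximal responses), compound 1 gives 126%, compound 2 gives 88% and compound 3 gives 175%. Compound 3 stands highest of the three numbers, and its separation from compound 1 as well as from compound 2 lies beyond the usual scatter. Among the compounds with values here, only one pair of measured compounds differs in a single place: a number 38 percentage points lower from compound 1 to compound 2 (beyond the scatter). That step shows how far a substituent change on the aromatic ring of the ester can move the maximal response.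

Compound 4 `CN(C)CCC(NC(=O)c1ccccc1)c1ccc(Cl)cc1` is the next compound. It differs from compound 3 as follows: hydrogen in place of methyl on an aromatic carbon. Within the data shown here, no measured step shares this change. The step from compound 1 to compound 2 touches the same ring, but it adds methoxy rather than removing methyl and runs in an ester rather than an amide, so it bears on compound 4 only as a sign that substitution on this ring matters. Compound 4 is therefore expected to show a number 35 percentage points lower from compound 3 to compound 4 (beyond the scatter). The estimate for compound 4 is 140%, with a range from 100% to 180%.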

Compound 4, largest response reached (reported as efficacy), in percent of the reference or control that the assay uses: 158%
Compound 4: middle estimate off by 18 percentage points, on the low side, and the stated range covers the measured number.
By their numbers in this assay, from the lowest: compound 2; then compound 1; then compound 4; then compound 3.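

In this assay, replacing the methyl of the 2-methylphenyl group with hydrogen gives a number 17 percentage points lower from compound 3 to compound 4 (beyond the scatter), a modest step at a position ortho to a large group. Within the data shown here, it is the first reading of this change, as compounds 1, 2 and 3 all keep the methyl on that ring and so could not show how the amide behaves without it. The methyl therefore adds measurably to the maximal response in this amide but is not required for a large one, since the unsubstituted phenyl of compound 4 still reaches 158%, and nothing on hand explains the drop, so it stands as an observation only.

The compounds shown leave open whether another group at this position, such as fluorine, chlorine, ethyl or an amine, would raise the maximal response above that of the methyl or lower it toward that of hydrogen. They also leave open whether the same removal of the methyl from the ester of compound 1 would move the response in the same direction and by a similar amount.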